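Swapping the ring-nitrogen substituent: compound 2 to compound 4

The source may hold more compounds than are shown below. What is called first, only, known or untested is meant among the compounds shown, and "the series" means these compounds.

Compound 2 `Cc1nc(S(C)(=O)=O)ccc1Oc1ncnc(OC2CCN(C(=O)O[C@H](C)C(F)(F)F)CC2)c1F` gives 110 nM in a functional assay on isolated protein for inhibition of Glucose-dependent insulinotropic receptor (Rattus norvegicus), read by HTRF and cAMP accumulation (on this read-out higher numbers stand for an effect only at larger amounts of compound and lower numbers for an effect already at smaller amounts), the second highest of three numbers. Its nearest neighbour is compound 1 `Cc1nc(S(C)(=O)=O)ccc1Oc1ncnc(OC2CCN(C(=O)OC(C)(C)CF)CC2)c1F`, which gives 138 nM; the change a 1.3-fold lower number from compound 1 to compound 2 (0.10 log units; within the scatter). Furthest lies compound 3 `Cc1nc(S(C)(=O)=O)ccc1Oc1ncnc(OC2CCN(C(=O)SC3CCC3)CC2)c1F` at 77.4 nM; the change a 1.4-fold lower number from compound 2 to compound 3 (0.15 log units; within the scatter), and likewise a 1.8-fold lower number from compound 1 to compound 3 (0.25 log units; within the scatter). Compound 4 `Cc1nc(S(C)(=O)=O)ccc1Oc1ncnc(OC2CCN(C(=S)OC(C)C)CC2)c1F` differs from compound 2 by a group of 6 heavy atoms (4 carbon, 1 oxygen, 1 sulfur; no ring) in place of a group of 9 heavy atoms (4 carbon, 2 oxygen, 3 fluorine; no ring), on an amine nitrogen in a ring. All three measured steps alter the group on that amine nitrogen in a ring, and none leaves the scatter, so no step beyond the scatter is expected here either. Compound 4 is therefore estimated at 105 nM, within 50 nM to 220 nM, which would be a step of a 1.0-fold lower number from compound 2 to compound 4 (0.02 log units; within the scatter) expected from compound 2.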

Compound 4, half-maximal effective concentration: 1050 nM
Compound 4: the middle estimate sits 10-fold (1.00 log units) below what was measured; measured number above the stated range.
By their numbers in this assay, from the lowest: compounds 3, 2 and 1 (each within the scatter of the next); then compound 4.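

Against the earlier steps, all within the scatter, the group on the amine nitrogen in a ring now matters in this assay with a 9.5-fold higher number from compound 2 to compound 4 (0.98 log units; beyond the scatter) and a 7.6-fold higher number from compound 1 to compound 4 (0.88 log units; beyond the scatter) and a 14-fold higher number from compound 3 to compound 4 (1.13 log units; beyond the scatter) as the first steps beyond the scatter at this place. Sulfur in this group does not alone go with the higher number, since compound 3 also carries sulfur there. Nothing measured here accounts for the change.

The compounds shown leave open whether an isopropoxycarbonyl group on that nitrogen, with oxygen in place of the sulfur of compound 4, would stay level with compound 2. Also open, going by these compounds, is whether the higher number follows the sulfur or the smaller size of the group.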